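Swapping methoxycarbonyl for methoxy on compound 3

The compounds below may be only part of what the source reports. "The series", "measured", "known", "first", "only" and "open" are said of these compounds alone.

Three close relatives have been tested in a functional assay on A549 cells (Homo sapiens) for inhibition, read by CCK-8 assay, with a stated time of 72 h, tested at 10 uM; a higher number here means more inhibition of growth at the concentration tested, a lower number less inhibition of growth: compound 1 `CN(C)C(=O)c1cc2cnc(Nc3ccc(NC(=O)C4(C(=O)Nc5ccccc5F)CC4)cc3)nc2n1C1CCCC1` gives 88.6%, compound 2 `CN(C)C(=O)c1cc2cnc(Nc3ccc(NC(=O)C4(C(=O)Nc5cccc(Cl)c5)CC4)cc3)nc2n1C1CCCC1` gives 90.7%, and compound 3 `COC(=O)c1cccc(NC(=O)C2(C(=O)Nc3ccc(Nc4ncc5cc(C(=O)N(C)C)n(C6CCCC6)c5n4)cc3)CC2)c1` gives 91%. Compound 3 therefore stands level with the other two, within the scatter. Compound 4 `COc1cccc(NC(=O)C2(C(=O)Nc3ccc(Nc4ncc5cc(C(=O)N(C)C)n(C6CCCC6)c5n4)cc3)CC2)c1` differs from it in one group: methoxy in place of methoxycarbonyl on an aromatic carbon. This places methoxy in place of methoxycarbonyl on an aromatic carbon. The closest evidence is a number 0.3 percentage points higher from compound 2 to compound 3 (within the scatter), which also involves the methoxycarbonyl group. The other two changes to this aromatic group, a number 2.1 percentage points higher from compound 1 to compound 2 (within the scatter) and a number 2.4 percentage points higher from compound 1 to compound 3 (within the scatter), were just as small. The expected step is a number 2 percentage points lower from compound 3 to compound 4 (within the scatter), with no change beyond the scatter foreseen. Compound 4 is estimated at 89%, within an expected range of 80% to 95%.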

Compound 4, percent growth inhibition at one concentration: 96%
Compound 4: the middle estimate sits 7 percentage points below what was measured; measured number above the stated range.
By their numbers in this assay, from the lowest: compounds 1, 2, 3 and 4 (each within the scatter of the next).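

Methoxy on this aromatic carbon keeps growth inhibition in this assay level with every other group tested here: the step is small against methoxycarbonyl (a number 5 percentage points higher from compound 3 to compound 4 (within the scatter)), chloro (a number 5.3 percentage points higher from compound 2 to compound 4 (within the scatter)) and the 2-fluorophenyl compound (a number 7.4 percentage points higher from compound 1 to compound 4 (within the scatter)). This position therefore accepts a smaller group without the double bond of methoxycarbonyl, and all four compounds remain within the scatter of one another. Nothing available explains these small steps. Still open, going by these compounds, is whether an amine or a carboxylic acid on this carbon would keep the same level of inhibition.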